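Chalcone-type series: chloro to methoxy swap on two cores

A few compounds are considered here, and "the series" means these few. Any claim that something is new, unique, unknown or untested is made for them only; others in the source may bear on it.

Measured so far:
- Compound 1, `O=C(/C=C/c1cccc(Cl)c1)c1nc2ccccc2s1`, gives in a functional assay on MCF7 cells (Homo sapiens) for antiproliferative activity, read by MTT assay, with a stated time of 48 h (a lower number here means a stronger inhibitor, a higher number a weaker inhibitor), only the assay limit > 100000 nM.
- Compound 2, `O=C(/C=C/c1cccc(Cl)c1)c1nc2ccccc2o1`, gives in this assay only the assay limit > 100000 nM.
- Compound 3, `COc1cccc(/C=C/C(=O)c2nc3ccccc3o2)c1`, gives in this assay only the assay limit > 100000 nM.

All three values recorded so far are limits rather than numbers, as noted under (the limit of > 100000 nM in this assay, at which 3 of the 3 values shown sit). Compound 1 and compound 2 carry different cores; the difference between the two cores is not broken down here. Compound 2 and compound 3 differ in one place only, (methoxy in place of chloro on an aromatic carbon), and the step that the two limits leave unreadable from compound 2 to compound 3 cannot be read because both ends sit at the limit.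

Compound 4, `COc1cccc(/C=C/C(=O)c2nc3ccccc3s2)c1`, is still to be measured. It differs from compound 1 by methoxy in place of chloro on an aromatic carbon. The place of this change is worded the same as for the step from compound 2 to compound 3, so it is the same change, made on the core of compound 1 instead of the core of compound 2.

For this assay the step from compound 1 to compound 4 is expected to be a step that the limit leaves unreadable from compound 1 to compound 4, which rests on compound 1 sitting at the limit > 100000 nM and on the same change leaving compound 3 at the limit > 100000 nM. Compound 4 is therefore expected to give about 200000 nM, with an expected range from 100000 nM to 1000000 nM, and most likely only a limit again.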

Compound 4, half-maximal inhibitory concentration: > 100000 nM
Compound 4 was reported as a limit (the forecaster's own chance of this, stated with the estimate: 85%); the middle value lies beyond the limit too.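

No step can be read from compound 1 to compound 4 in this assay, and the same holds for the earlier swap from compound 2 to compound 3, because the values are limits and not numbers: the limit of > 100000 nM in this assay, at which 4 of the 4 values shown sit.

The compounds shown leave open whether methoxy in place of chloro changes potency on either core, and whether the two cores differ at all in this assay.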